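Methyl to Fluoro: Expecting Little Change in Growth Inhibition

This account rests on a few compounds, and the source may have more. Where it says the series, first, only, none or still open, it means among the compounds named here.

Compound 1 `Cc1ccc(SCc2ccc(C(=O)Nc3ccccc3N)cc2)cc1` was tested in a functional assay on A-375 cells (Homo sapiens) for inhibition, read by CCK-8 assay, with a stated time of 72 h, tested at 2 uM (on this read-out lower numbers stand for less inhibition of growth and higher numbers for more inhibition of growth at the one concentration tested), where compound 1 gives 17.5%. For the measured compounds named here, only one other compound has been measured: compound 2 `Nc1ccccc1NC(=O)/C=C/c1ccc(CSc2ccc(C(F)(F)F)cn2)cc1` gives 10.3% in this assay. Going by the values given here, compound 1 is the one with the larger reading of the two, but the gap between them is within the scatter, so neither can be said to stand apart from the other. Compound 3 `Nc1ccccc1NC(=O)c1ccc(CSc2ccc(F)cc2)cc1` has not yet been measured. It differs from compound 1 in one place: fluoro in place of methyl on an aromatic carbon. Among the compounds with values here, no measured pair shows what this swap does in this assay, so there is no step to lean on. With both measured numbers close together, the expected step of a number 1.5 percentage points lower from compound 1 to compound 3 (within the scatter) is small, with no clear direction, and not beyond the scatter. Compound 3 is therefore estimated at 16%, with a range from 5% to 28%.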

Compound 3, percent growth inhibition at one concentration: 19.4%
The estimate for compound 3 lay 3.4 percentage points below the measured number; the measured number falls inside the stated range.
By their numbers in this assay, from the lowest: compounds 2, 1 and 3 (each within the scatter of the next).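

For the compounds shown here, this pair gives the first direct look at this position: with fluoro in place of methyl on an aromatic carbon, para to a large group, this assay shows a number 1.9 percentage points higher from compound 1 to compound 3 (within the scatter). The 4-methylphenyl and 4-fluorophenyl forms therefore cannot be told apart in this measurement, and on the core of compound 1 this one swap leaves the reading within the usual scatter. Nothing available here explains why the two groups read alike.

On these data alone, whether an amine, a carboxylic acid or a longer chain at the same aromatic carbon would give a step beyond the scatter remains open. As far as these compounds go, this swap also rests on one pair, so its effect on any other core is unknown.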